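The compounds below may be only part of what the source reports. "The series", "measured", "known", "first", "only" and "open" are said of these compounds alone.

Working notes on the series, all read in a functional assay on NCI-H146 cells (Homo sapiens) for cytotoxicity, with a stated time of 48 h, in the presence of a further agent that is not named here (a higher number here means that more compound is needed for the effect, a lower number that less compound is needed), as the only measure. Compound 1 (`CN(C)CC[C@H](CSc1ccccc1)Nc1ccc(S(=O)(=O)NC(=O)c2ccc(N3CCN(Cc4ccccc4-c4ccc(Cl)cc4)CC3)cc2)cc1S(C)(=O)=O`) carries methylsulfonyl and gives 34900 nM in this measure. Compound 2 (`CN(C)CC[C@H](CSc1ccccc1)Nc1ccc(S(=O)(=O)NC(=O)c2ccc(N3CCN(Cc4ccccc4-c4ccc(Cl)cc4)CC3)cc2)cc1`) carries hydrogen instead and gives 78700 nM here. Compound 3 (`CN(C)CC[C@H](CSc1ccccc1)Nc1ccc(S(=O)(=O)NC(=O)c2ccc(N3CCN(Cc4ccccc4-c4ccc(Cl)cc4)CC3)cc2)cc1OC(F)(F)F`) carries trifluoromethoxy and gives 5080 nM as the lowest of the three numbers, beyond the scatter from both others.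

Compound 4 (`CN(C)CC[C@H](CSc1ccccc1)Nc1ccc(S(=O)(=O)NC(=O)c2ccc(N3CCN(Cc4ccccc4-c4ccc(Cl)cc4)CC3)cc2)cc1C#N`) has cyano in place of trifluoromethoxy on an aromatic carbon. Among the compounds with values here, three measured steps bear on this change. The large one is a 15-fold lower number from compound 2 to compound 3 (1.19 log units; beyond the scatter) on going from hydrogen to trifluoromethoxy. The modest one is a 6.9-fold lower number from compound 1 to compound 3 (0.84 log units; beyond the scatter) on going from methylsulfonyl to trifluoromethoxy. Hydrogen against methylsulfonyl is also modest at a 2.3-fold higher number from compound 1 to compound 2 (0.35 log units; beyond the scatter) on that carbon. Cyano itself has no measured precedent here, but both other groups stand well above compound 3, so a modest rise is expected. The estimated step is a 4.9-fold higher number from compound 3 to compound 4 (0.69 log units; beyond the scatter) in this assay on this reading. For compound 4 the expected value is 25000 nM with an estimated range of 9000 nM to 70000 nM in this measure.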

Compound 4, half-maximal effective concentration: 1930 nM
Compound 4: the middle estimate sits 13-fold (1.11 log units) above what was measured, and the stated range ends above it.
By their numbers in this assay, from the lowest: compound 4; then compound 3; then compound 1; then compound 2.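

In this assay, cyano on this aromatic carbon gives a 2.6-fold lower number from compound 3 to compound 4 (0.42 log units; beyond the scatter), so the 5 heavy atoms of trifluoromethoxy are not required for a low number here: a group of 2 heavy atoms goes further. Cyano also stands well clear of the other two groups at this position, with a 41-fold lower number from compound 2 to compound 4 (1.61 log units; beyond the scatter) and an 18-fold lower number from compound 1 to compound 4 (1.26 log units; beyond the scatter), which places the four groups, from the lowest number, as cyano, trifluoromethoxy, methylsulfonyl and hydrogen. No supporting data are available to account for this order.

The compounds shown leave open whether a chlorine atom, a trifluoromethyl group or a primary carboxamide on this carbon would extend or break the order. They also leave open whether the order would hold if the cyano group sat on another carbon of this ring.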